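Benzyl amide series: methoxy for methyl at the para position

The compounds below may be only part of what the source reports. "The series", "measured", "known", "first", "only" and "open" are said of these compounds alone.

Measured compounds:
- compound 1, `COc1ccc(CNC(=O)CC2c3ccccc3N=C(N(C)CCCCCN(C)C)N2c2ccc(-c3ccccc3)cc2)cc1`: 390 nM
- compound 2, `CN(C)CCN1CCN(C2=Nc3ccccc3C(CC(=O)NCc3ccccc3)N2c2ccc(-c3ccccc3)cc2)CC1`: "not determined" (no result reported)
- compound 3, `Cc1ccc(CNC(=O)CC2c3ccccc3N=C(N3CCN(CCN(C)C)CC3)N2c2ccc(-c3ccccc3)cc2)cc1`: 460 nM

In an assay on HEK293 cells for inhibition of Voltage-dependent T-type calcium channel subunit alpha-1G (Homo sapiens), read by patch clamp (a lower number here means a stronger inhibitor, a higher number a weaker inhibitor), compound 3 gives 460 nM and compound 1 gives 390 nM; the two numbers lie within the scatter of each other, so no order between them can be read. Compound 2 carries the same amidine substituent as compound 3 but an unsubstituted benzyl amide, and for compound 2 this assay returned no number. Going by the values given here, compound 3 thus stands alongside compound 1 as one of only two numbers, with nothing further to rank it against.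

Compound 4, `COc1ccc(CNC(=O)CC2c3ccccc3N=C(N3CCN(CCN(C)C)CC3)N2c2ccc(-c3ccccc3)cc2)cc1`, differs from compound 3 in one place: methoxy in place of methyl on an aromatic carbon. Among the compounds with values here, no measured pair shows this change directly. Compound 1 already carries the methoxy group and gives 390 nM, which sits within the scatter of compound 3; on that basis the step of a 1.2-fold lower number from compound 3 to compound 4 (0.06 log units; within the scatter) is expected to stay within the scatter, in no set direction. Compound 4 is therefore estimated at 400 nM in this assay, with a range of 150 nM to 1100 nM.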

Compound 4, half-maximal inhibitory concentration: 310 nM
Beside the measured number, compound 4's estimate is 1.3-fold (0.11 log units) above it, within the range that was stated.
By their numbers in this assay, from the lowest: compounds 4, 1 and 3 (each within the scatter of the next).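

Methoxy in place of methyl on the aromatic carbon para to a large group now has a direct pair in this assay: a 1.5-fold lower number from compound 3 to compound 4 (0.17 log units; within the scatter), so 4-methylbenzyl and 4-methoxybenzyl cannot be told apart at this position. With 4-methoxybenzyl held fixed, the second pair gives a 1.3-fold lower number from compound 1 to compound 4 (0.10 log units; within the scatter), so 4-(2-(dimethylamino)ethyl)piperazin-1-yl and (5-(dimethylamino)pentyl)(methyl)amino also cannot be told apart on the carbon with a double bond to nitrogen. No available evidence bears on either result.

From the compounds shown here alone, it remains open whether a group such as a carboxylic acid or a primary amine on the same aromatic carbon would give a step beyond the scatter. Compound 2 has no reported number, so the unsubstituted benzyl amide offers no reference for either 4-substituted benzyl group.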